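Ester to Amide at the Benzylic Aryl Position

This account rests on a few compounds, and the source may have more. Where it says the series, first, only, none or still open, it means among the compounds named here.

Measured so far:
compound 1 `NCc1cc(C(F)(F)F)ccc1CN(Cc1nc2ccccc2[nH]1)C1CCCc2cccnc21` — in a functional assay on CEM-CCRF cells for antagonist activity at C-X-C chemokine receptor type 4 (Homo sapiens), read by calcium flux (a higher number here means a weaker inhibitor, a lower number a stronger inhibitor), compound 1 gives 51 nM
compound 2 `NCc1cc(CO)ccc1CN(Cc1nc2ccccc2[nH]1)C1CCCc2cccnc21` — compound 2 gives 11 nM
compound 3 `COC(=O)c1ccc(CN(Cc2nc3ccccc3[nH]2)C2CCCc3cccnc32)c(CN)c1` — compound 3 gives 39 nM

Compound 3 stands second highest of these three numbers: it sits within the scatter of compound 1, with a 1.3-fold lower number from compound 1 to compound 3 (0.12 log units; within the scatter), but clearly apart from compound 2, with a 3.5-fold higher number from compound 2 to compound 3 (0.55 log units; beyond the scatter).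

Compound 4 `NCc1cc(C(N)=O)ccc1CN(Cc1nc2ccccc2[nH]1)C1CCCc2cccnc21` differs from compound 3 in one place: amino in place of methoxy on a carbonyl carbon. Among the measured compounds shown here, two measured steps bear on this. Replacing trifluoromethyl with hydroxymethyl gave a 4.6-fold lower number from compound 1 to compound 2 (0.67 log units; beyond the scatter), and going from that hydroxymethyl to the methoxycarbonyl gave a 3.5-fold higher number from compound 2 to compound 3 (0.55 log units; beyond the scatter). In both, the compound carrying a group with a hydrogen-bond donor on this aromatic carbon had the lower number. The new amino group enters with a donor as well, so a modest downward step is expected, but the data cannot show how far toward compound 2 it will go.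

Compound 4 is therefore expected to show a 2.2-fold lower number from compound 3 to compound 4 (0.34 log units; beyond the scatter), landing at an estimated 18 nM in this assay, within a range of 8 nM to 45 nM.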

Compound 4, half-maximal inhibitory concentration: 15 nM
Estimate against measurement, compound 4: 1.2-fold (0.08 log units) above, within the range that was stated.
By their numbers in this assay, from the lowest: compounds 2 and 4 (each within the scatter of the next); then compounds 3 and 1 (each within the scatter of the next).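

In this assay, swapping methoxy for amino on the carbonyl carbon gives a 2.6-fold lower number from compound 3 to compound 4 (0.41 log units; beyond the scatter), so the ester and the amide do not behave alike here even though both keep the carbonyl. The carbamoyl group also gives a 3.4-fold lower number from compound 1 to compound 4 (0.53 log units; beyond the scatter), while a 1.4-fold higher number from compound 2 to compound 4 (0.13 log units; within the scatter) leaves it indistinguishable from hydroxymethyl, so the four compounds now form two pairs, with the groups that carry a hydrogen-bond donor in the lower pair and no compound shown going against that split. Nothing available here explains the split.

The compounds shown leave open how a carboxylic acid, an N-methyl amide or an aminomethyl group on this aromatic carbon would compare. An N,N-dimethyl amide would test further whether the amide hydrogen matters, since the donor pattern rests on only four compounds.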